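The source may report more compounds than this note shows. Statements on the series, on what has been measured and on what is new or still open speak of the compounds shown alone.

In a physicochemical assay for lipophilicity, using the shake flask method, at pH 7.4 (on this read-out lower numbers stand for lower lipophilicity and higher numbers for higher lipophilicity), the measured compounds are:

- compound 1 `CC(=O)N1CCN([C@H]2CC[C@H](Nc3ncnn4ccc([C@H]5CC[C@H](C(N)=O)CC5)c34)CC2)CC1` gives 1.4
- compound 2 `CN(C)[C@H]1CC[C@H](Nc2ncnn3ccc(C4CCOCC4)c23)CC1` gives 0.5
- compound 3 `CC(C)c1ccn2ncnc(N[C@H]3CC[C@H](N(C)C)CC3)c12` gives 1.3

Compound 3 stands within the scatter of compound 1 and beyond the scatter from compound 2, which makes it one of the upper pair of this small set.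

Compound 4 `CN(C)[C@H]1CC[C@H](Nc2ncnn3ccc([C@H]4CC[C@H](C(N)=O)CC4)c23)CC1` has not yet been measured. Its difference from compound 3 is 4-carbamoylcyclohexyl in place of isopropyl on an aromatic carbon, which puts 4-carbamoylcyclohexyl in place of isopropyl on an aromatic carbon.

Among the compounds with values here, one measured step bears on this change, because it concerns the same aromatic carbon and the same isopropyl group: a number 0.80 log units higher from compound 2 to compound 3 (beyond the scatter). That step is modest and beyond the scatter. Compound 4 gives up the isopropyl group just as compound 2 lacks it, so a modest step downward in this assay is expected, of similar size. Within the data shown here, no measured step has 4-carbamoylcyclohexyl as its changing group, so this reading is only an analogy and the range is kept wide.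

The step expected on this basis is a number 0.60 log units lower from compound 3 to compound 4 (beyond the scatter), an estimate and not a measurement.

For compound 4 the estimated value is 0.7, with an expected range from 0.2 to 1.2.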

Compound 4, distribution coefficient: 0.2
Compound 4: the middle estimate sits 0.50 log units above what was measured; measured number inside the range.
By their numbers in this assay, from the lowest: compounds 4 and 2 (each within the scatter of the next); then compounds 3 and 1 (each within the scatter of the next).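

In this assay the aromatic carbon two ring bonds from the ring nitrogen now has a third group on record: the step of a number 1.10 log units lower from compound 3 to compound 4 (beyond the scatter) sets 4-carbamoylcyclohexyl well apart from isopropyl, while the step of a number 0.30 log units lower from compound 2 to compound 4 (within the scatter) leaves 4-carbamoylcyclohexyl and oxan-4-yl indistinguishable on this read-out. Among these three compounds, the separation at this carbon therefore lies between isopropyl and the two larger groups, with no separation between those two. With 4-carbamoylcyclohexyl held constant, the saturated ring carbon also gives a large change, as the step of a number 1.20 log units lower from compound 1 to compound 4 (beyond the scatter) shows for dimethylamino in place of 4-acetylpiperazin-1-yl, and no measurement at hand accounts for any of these steps.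

The compounds shown leave open how the 4-carbamoylcyclohexyl result divides between the cyclohexyl ring and its carboxamide, a question that an unsubstituted cyclohexyl group or a cyclohexyl ring bearing a carboxylic acid or a nitrile at the same carbon could address. Also open, as far as these compounds go, is whether the other stereoisomer of 4-carbamoylcyclohexyl would sit level with oxan-4-yl on this read-out.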